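A few compounds are considered here, and "the series" means these few. Any claim that something is new, unique, unknown or untested is made for them only; others in the source may bear on it.

Measured in an ADME assay on microsomes from liver (Rattus norvegicus) for metabolic stability, read by LC-MS, with a stated time of 10 min, tested at 0.5 uM; on this read-out higher numbers stand for a more stable compound and lower numbers for a less stable compound:
compound 1 `CN1CCN(CCCN(C[C@H]2Cc3ccccc3CN2)[C@H]2CCCc3cccnc32)CC1` gives 10%
compound 2 `NC(=O)N1CCN(CCCN(C[C@H]2Cc3ccccc3CN2)[C@H]2CCCc3cccnc32)CC1` gives 4%

Compound 1 holds the highest of the two numbers only nominally, since the step of a number 6 percentage points lower from compound 1 to compound 2 (within the scatter) is within the scatter; both compounds sit low in this assay. Compound 3 `CN1CCN(CCCN(C[C@H]2Cc3ccccc3CN2C)[C@H]2CCCc3cccnc32)CC1` differs from compound 1 by methyl in place of hydrogen on an amine nitrogen in a ring. For the measured compounds named here, the only measured step, a number 6 percentage points lower from compound 1 to compound 2 (within the scatter), concerns a different substitution at another ring amine nitrogen and bears on this change only loosely, showing no movement beyond the scatter. No step beyond the scatter is therefore expected. Compound 3 is estimated at 8% (range 2% to 20%), an expected step of a number 2 percentage points lower from compound 1 to compound 3 (within the scatter).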

Compound 3, percent of the compound remaining: 2%
Compound 3: middle estimate off by 6 percentage points, on the high side, and the stated range covers the measured number.
By their numbers in this assay, from the lowest: compounds 3, 2 and 1 (each within the scatter of the next).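

Methyl in place of hydrogen on this amine nitrogen in a ring, next to the ring atom that bears a large group, gives a number 8 percentage points lower from compound 1 to compound 3 (within the scatter) in this assay. The earlier step at the other ring amine nitrogen, a number 6 percentage points lower from compound 1 to compound 2 (within the scatter), was also within the scatter, so neither change separates the compounds in this assay. Nothing at hand explains this result.

From the compounds shown here alone, whether an acetyl or a longer chain such as propyl on this nitrogen would move the number beyond the scatter stays open. So does the effect of a carboxylic acid on the piperazine-bearing chain.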